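The source may hold more compounds than are shown below. What is called first, only, known or untested is meant among the compounds shown, and "the series" means these compounds.

Compounds measured so far in a functional assay on HL-60 cells (Homo sapiens) for antiproliferative activity, with a stated time of 24 h; on this read-out lower numbers stand for stronger inhibition and higher numbers for weaker inhibition:
- compound 1 `NC(=O)c1c(NC(=O)c2ccccc2Cl)sc2c1CCN(C(=S)Nc1cccc3ccccc13)C2` gives 13400 nM
- compound 2 `Cc1ccccc1C(=O)Nc1sc2c(c1C(N)=O)CCN(C(=S)Nc1ccccc1Cl)C2` gives 20900 nM

Compound 2 holds the highest of the two numbers in this assay, and its nearest neighbour is compound 1, whose number is lower by a gap that stays within the usual scatter. The two differ in more than one place, so nothing is to be drawn from them about any single change; their values show only that both sit in the same weak range.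

Compound 3 `NC(=O)c1c(NC(=O)c2ccncn2)sc2c1CCN(C(=S)Nc1ccccc1Cl)C2` is the next compound to be measured. It keeps the core of compound 2 and changes one place: pyrimidin-4-yl in place of 2-methylphenyl on a carbonyl carbon. Within the data shown here, no measured pair in the set carries this change, so there is no step to lean on, and nothing in the two values shown points in either direction for it.

The expectation for compound 3 is therefore a step from compound 2 of a 1.1-fold higher number from compound 2 to compound 3 (0.02 log units; within the scatter), no larger than the scatter. Compound 3 is estimated at 22000 nM in this assay, in a range from 7000 nM to 70000 nM.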

Compound 3, half-maximal inhibitory concentration: 34600 nM
Compound 3: middle estimate off by 1.6-fold (0.20 log units), on the low side; the measured number falls inside the stated range.
By their numbers in this assay, from the lowest: compounds 1, 2 and 3 (each within the scatter of the next, the first and the last beyond it).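

In this assay the series now has its first step in one place: a 1.7-fold higher number from compound 2 to compound 3 (0.22 log units; within the scatter) for pyrimidin-4-yl in place of 2-methylphenyl on a carbonyl carbon. At this position, a six-membered aromatic ring of carbon only gives way to one with hetero atoms and hydrogen-bond acceptors, yet the numbers for the two compounds cannot be told apart. This single step gives no sign that the 2-methylphenyl group is required and no sign that pyrimidin-4-yl improves the read-out, and both compounds stay in the same weak range.

Still open, on these data alone, is whether any group on this carbonyl carbon can move the number beyond the scatter, for instance a saturated ring such as cyclohexyl, a short chain such as ethyl, or an aromatic ring bearing an amine or a carboxylic acid. Also open, as far as these compounds go, is whether this step would read the same with the other end of the shared core changed.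

No outside evidence bears on this result.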